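Methyl and methylsulfonyl steps on a shared benzylidene ketone core

The source may hold more compounds than are shown below. What is called first, only, known or untested is meant among the compounds shown, and "the series" means these compounds.

Measured so far:
Compound 1, `CN(CC1CCC/C(=C\c2ccccc2)C1=O)c1ccccc1`: 76.6%
Compound 2, `Cc1cccc(N(C)CC2CCC/C(=C\c3ccccc3)C2=O)c1`: 46.8%
Compound 3, `CN(CC1CCC/C(=C\c2ccc(S(C)(=O)=O)cc2)C1=O)c1ccccc1`: 51.1%

All three were tested in a functional assay on the whole organism (strain Wistar) for inhibition, with Rattus norvegicus as the target, read by paw edema, with stated times of 1 h and 3 h, at a dose of 200 mg/kg by the oral route; a higher number here means more inhibition at the dose given (going by the name of the read-out), a lower number less inhibition. Compound 1 gives the highest of the three numbers, 76.6%. Compound 2 carries one change relative to compound 1, (methyl in place of hydrogen on an aromatic carbon), and the result is a number 29.8 percentage points lower from compound 1 to compound 2 (beyond the scatter). Compound 3 carries a different change relative to compound 1, (methylsulfonyl in place of hydrogen on an aromatic carbon), with the result a number 25.5 percentage points lower from compound 1 to compound 3 (beyond the scatter). Compound 2 and compound 3 lie within the scatter of each other, so nothing separates them.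

Compound 4, `Cc1ccc(N(C)CC2CCC/C(=C\c3ccc(S(C)(=O)=O)cc3)C2=O)cc1`, has not yet been measured. It differs from compound 3 by methyl in place of hydrogen on an aromatic carbon. This is the same kind of change that turns compound 1 into compound 2, but not the same: in compound 2 the methyl sits meta to a large group, in compound 4 it sits para to a large group. The cores also differ, as described by methylsulfonyl in place of hydrogen on an aromatic carbon.

For the measured compounds named here, the only methyl step seen here lowered the number, a number 29.8 percentage points lower from compound 1 to compound 2 (beyond the scatter), and on that basis a drop is expected from compound 3 to compound 4 in this assay, estimated as a number 18.1 percentage points lower from compound 3 to compound 4 (beyond the scatter). The different place of the methyl leaves this uncertain. Compound 4 is expected to give about 33%, estimated between 12% and 58%.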

Compound 4, a percentage reported as inhibition, in the whole organism at one dose (the size of the read-out at that dose, not a potency): 31.9%
Compound 4: the middle estimate sits 1.1 percentage points above what was measured; measured number inside the range.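

Replacing phenyl with 4-methylphenyl on the amine of compound 3 gives, in this assay, a number 19.2 percentage points lower from compound 3 to compound 4 (beyond the scatter). Set beside the earlier methyl step, the change lowers the number on both cores, and the two drops cannot be told apart: the same change on two cores in this assay, a number 29.8 percentage points lower (beyond the scatter) from compound 1 to compound 2 and a number 19.2 percentage points lower (beyond the scatter) from compound 3 to compound 4, 10.6 percentage points apart, within the scatter of two such steps. This suggests that, in these two pairs, the methyl step carries over from one core to the other in direction and roughly in size, but two pairs do not make a rule for other cores, the methyl sits at a different place on the ring in each pair, and nothing here shows why the number falls.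

The compounds shown leave open whether the drop belongs to the methyl itself or would also come with another group at the same place, such as a chlorine atom, a methoxy group or a longer chain like ethyl. They also leave open how a methyl at one fixed place would behave on both cores, and whether the methylsulfonyl step, seen so far on the core of compound 1 alone, would repeat elsewhere, or how a carboxylic acid in its place would read.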